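Lengthening the hydroxamic acid arm of compound 3

A few compounds are considered here, and "the series" means these few. Any claim that something is new, unique, unknown or untested is made for them only; others in the source may bear on it.

Compound 1 `O=C(/C=C/c1ccc(CN2C(=O)/C(=C3\Nc4ccccc4\C3=N/O)c3cc(Br)ccc32)cc1)NO`: 9 nM
Compound 2 `COc1ccc2c(c1)/C(=C1/Nc3ccccc3/C1=N\O)C(=O)N2Cc1ccc(/C=C/C(=O)NO)cc1`: 50 nM
Compound 3 `O=C(NO)c1ccc(CN2C(=O)/C(=C3\Nc4ccccc4\C3=N/O)c3cc(F)ccc32)cc1`: 30 nM

In a functional assay on NCI-H23 cells (Homo sapiens) for cytotoxicity, read by colorimetric assay (a higher number here means a weaker inhibitor, a lower number a stronger inhibitor), compound 3 stands second highest of the three numbers; its value is within the scatter of compound 2 and beyond the scatter of compound 1. Compound 4 `O=C(/C=C/c1ccc(CN2C(=O)/C(=C3\Nc4ccccc4\C3=N/O)c3cc(F)ccc32)cc1)NO` differs from compound 3 in one place: 2-(hydroxycarbamoyl)ethenyl in place of hydroxycarbamoyl on an aromatic carbon. Among the measured compounds shown here, no measured step follows this exact change. For the measured compounds named here, the only measured step, a 5.6-fold higher number from compound 1 to compound 2 (0.74 log units; beyond the scatter), concerns a different place. Compounds 1 and 2, which already carry the entering group, give the lowest and the highest numbers shown, so the arm itself is not tied to a direction. For compound 4 a step of a 2.0-fold lower number from compound 3 to compound 4 (0.30 log units; within the scatter) is expected, a small shift toward lower numbers. Compound 4 is estimated at 15 nM, in the range 5 nM to 45 nM.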

Compound 4, half-maximal inhibitory concentration: 8 nM
Estimate against measurement, compound 4: 1.9-fold (0.27 log units) above; low and high end bracket the measured number.
By their numbers in this assay, from the lowest: compounds 4 and 1 (each within the scatter of the next); then compounds 3 and 2 (each within the scatter of the next).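

In this assay, the arm itself now has a measured effect at this place: 2-(hydroxycarbamoyl)ethenyl in place of hydroxycarbamoyl gives a 3.8-fold lower number from compound 3 to compound 4 (0.57 log units; beyond the scatter). With that arm held constant, fluoro in place of methoxy gives a 6.3-fold lower number from compound 2 to compound 4 (0.80 log units; beyond the scatter), whereas fluoro in place of bromo gives a 1.1-fold lower number from compound 1 to compound 4 (0.05 log units; within the scatter), so fluoro and bromo cannot be told apart here. Nothing available explains these steps. Going by these compounds, whether the arm change gives a similar step with bromo or methoxy on the core remains open. So does the effect of a longer chain carrying the hydroxycarbamoyl group, or of a carboxylic acid in its place.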